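The source may report more compounds than this note shows. Statements on the series, on what has been measured and on what is new or still open speak of the compounds shown alone.

Measured in an assay for inhibition of high affinity nerve growth factor receptor (Homo sapiens), read by HTRF, with a stated time of 30 min, in the presence of a further agent that is not named here; a higher number here means a weaker inhibitor, a lower number a stronger inhibitor:
Compound 1, `Cc1cc(Nc2nc(NCc3ccc(Cl)cc3)nc3ccccc23)n[nH]1`, gives 380 nM.
Compound 2, `Cc1cc(Nc2nc(NCc3ccc(C(F)(F)F)cc3)nc3ccccc23)n[nH]1`, gives 1400 nM.

Within the data shown here, compound 2 stands with the highest number of these two, meaning the weaker inhibitor; its nearest neighbour is compound 1, and the only measured step, a 3.7-fold higher number from compound 1 to compound 2 (0.57 log units; beyond the scatter), lies beyond the scatter and arises from trifluoromethyl in place of chloro on an aromatic carbon.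

Compound 3, `Cc1cc(Nc2nc(NCc3ccc(OC(F)(F)F)cc3)nc3ccccc23)n[nH]1`, is the not yet measured compound. It differs from compound 2 in one place: trifluoromethoxy in place of trifluoromethyl on an aromatic carbon, para to a large group. Among the measured compounds shown here, no measured step swaps trifluoromethyl for trifluoromethoxy, so the step from compound 1 to compound 2 bears only indirectly, showing that a change at this position can move the number by a modest amount. The swap here keeps the three fluorines and adds one oxygen, so for compound 3 the expected step is a 1.3-fold lower number from compound 2 to compound 3 (0.10 log units; within the scatter), which is estimated to stay within the scatter. Compound 3 is therefore estimated at 1100 nM, with a range from 400 nM to 3500 nM.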

Compound 3, half-maximal inhibitory concentration: 4100 nM
For compound 3 the middle estimate is 3.7-fold (0.57 log units) below the measured one; the measured number lies above the stated range.
By their numbers in this assay, from the lowest: compound 1; then compound 2; then compound 3.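

Swapping trifluoromethyl for trifluoromethoxy adds only one oxygen, yet this position still responds to it: in this assay the swap gives a 2.9-fold higher number from compound 2 to compound 3 (0.47 log units; beyond the scatter), so two fluorine-bearing groups that look alike on paper are clearly told apart here. Measured against chloro, the same group gives an 11-fold higher number from compound 1 to compound 3 (1.03 log units; beyond the scatter), and the three compounds now fall into one order at this position, with chloro giving the lowest number, then trifluoromethyl, then trifluoromethoxy. No measurement at hand explains why the number rises along this series, so the order stands as an observation only.

The compounds shown leave open whether a bare hydrogen, a fluoro, a methoxy, an amine or a carboxylic acid at this position would continue the order or give a number lower than that of compound 1, so chloro cannot yet be taken as the best choice here. From the compounds shown here alone, it also remains open whether the same order would hold for these groups elsewhere on the ring, or on a changed version of the shared core.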